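Compound 3: an amide replaces the free acid of compound 1

The source may report more compounds than this note shows. Statements on the series, on what has been measured and on what is new or still open speak of the compounds shown alone.

Compound 1 `O=C(O)CCC(=O)OCCCCCCSc1ccc([N+](=O)[O-])c2nonc12` has been tested in an ADME assay on L02 cells (Homo sapiens) for cytotoxicity, read by MTT assay, with a stated time of 72 h (on this read-out lower numbers stand for stronger inhibition and higher numbers for weaker inhibition), where compound 1 gives 1890 nM, the lowest of the two numbers recorded. Its companion, compound 2 `COc1ccc(NC(=O)CCC(=O)OCCCCCCSc2ccc([N+](=O)[O-])c3nonc23)cc1OC`, carries an amide in place of the free acid and gives 4100 nM; that single change is a step of a 2.2-fold higher number from compound 1 to compound 2 (0.34 log units; beyond the scatter). Compound 3 `CN(C)CCCNC(=O)CCC(=O)OCCCCCCSc1ccc([N+](=O)[O-])c2nonc12` is not yet measured. It differs from compound 1 at the same point: (3-(dimethylamino)propyl)amino in place of hydroxy on a carbonyl carbon. Among the measured compounds shown here, the group that enters, (3-(dimethylamino)propyl)amino, is a chain rather than a ring, so the earlier step is the only guide and need not repeat exactly. Still, turning the acid into an amide once weakened inhibition modestly, and a similar move, a 1.7-fold higher number from compound 1 to compound 3 (0.23 log units; within the scatter), is expected here. Compound 3 is therefore estimated to give 3200 nM in this assay, with a plausible range from 1500 nM to 7000 nM.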

Compound 3, half-maximal inhibitory concentration: 4230 nM
Compound 3: the middle estimate sits 1.3-fold (0.12 log units) below what was measured, within the range that was stated.
By their numbers in this assay, from the lowest: compound 1; then compounds 2 and 3 (each within the scatter of the next).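

In this assay, putting (3-(dimethylamino)propyl)amino in place of hydroxy on the carbonyl carbon gives a 2.2-fold higher number from compound 1 to compound 3 (0.35 log units; beyond the scatter) and so shows a second amide, this time with a chain and no ring, parting from the free acid as the first amide did. Exchanging 3,4-dimethoxyphenyl for 3-(dimethylamino)propyl on the amide-type nitrogen gives a 1.0-fold higher number from compound 2 to compound 3 (0.01 log units; within the scatter) and so these two amides cannot be told apart here, despite their very different groups. Nothing available explains this result.

From the compounds shown here alone, it remains open whether a shorter or longer chain ending in the same dimethylamino group would read like these two amides. Also open, going by these compounds, is how a plain amide, with only hydrogens on its nitrogen, or a methyl ester in place of the free acid would compare.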